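A Bromo for a Chloro on the Sulfonyl Arm

The source may report more compounds than this note shows. Statements on the series, on what has been measured and on what is new or still open speak of the compounds shown alone.

Compound 1, `COc1ccc(-c2cc(=O)c3c(OC)cc(OC)cc3n2Cc2ccccc2)cc1`, in a functional assay on SUP-B15 cells (Homo sapiens) for antiproliferative activity, with a stated time of 72 h (a higher number here means that more compound is needed for the effect, a lower number that less compound is needed), gives > 34400 nM, which is a limit of the assay and not a number.
Compound 2, `COc1ccc(-c2cc(=O)c3c(OC)cc(OC)cc3n2S(=O)(=O)c2ccc(C)c([N+](=O)[O-])c2)cc1`, in this assay gives > 51700 nM, again only a limit.
Compound 3, `COc1ccc(-c2cc(=O)c3c(OC)cc(OC)cc3n2S(=O)(=O)c2ccc(Cl)cc2)cc1`, in this assay gives > 34400 nM, also a limit.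

Compound 3 therefore stands at the limit of > 34400 nM in this assay, at which 2 of the 3 values shown sit, shared with compound 1, while compound 2 stands at the limit of > 51700 nM in this assay, at which 1 of the 3 values shown sits. Two steps lead to compound 3 within the measured set: a step that the two limits leave unreadable from compound 1 to compound 3 and a step that the two limits leave unreadable from compound 2 to compound 3. Since all three values are limits, neither step has a readable size or direction; what the three compounds show together is that three quite different substituents on the aromatic nitrogen of the shared core all leave the potency beyond the reach of this assay.

Compound 4, `COc1ccc(-c2cc(=O)c3c(OC)cc(OC)cc3n2S(=O)(=O)c2ccc(Br)cc2)cc1`, differs from compound 3 by bromo in place of chloro on an aromatic carbon. Both measured steps concern this same nitrogen substituent, yet neither can say how much a change there moves the value. With no readable step to lean on, the expectation is a step that the limit leaves unreadable from compound 3 to compound 4 in this assay, that is, nothing beyond the usual scatter, and most likely another limit. Compound 4 is thus estimated to give 45000 nM, with an expected range from 20000 nM to 100000 nM.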

Compound 4, half-maximal effective concentration: 63800 nM
The estimate for compound 4 lay 1.4-fold (0.15 log units) below the measured number; the range from low to high includes it.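

Compound 1, compound 2 and compound 3 give only limits in this assay, while compound 4 gives a number; none of the steps from those three to compound 4 can be read. The compounds shown leave open whether bromo and chloro differ at all, and whether any substituent on the aromatic nitrogen changes potency.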